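Cyclopropyl Added to the Fused Core of Compound 1

A few compounds are considered here, and "the series" means these few. Any claim that something is new, unique, unknown or untested is made for them only; others in the source may bear on it.

Measured compounds:
compound 1 `Cc1c(C(C)OC(=O)Nc2ccccc2)oc2ncnn12` – 63.1 nM
compound 2 `Cc1c(C(C)OC(=O)Nc2ccccc2Cl)oc2ncnn12` – 501 nM

Of the compounds shown here, two have been measured in a functional assay on CHO cells for antagonist activity at metabotropic glutamate receptor 5 (Homo sapiens), read by calcium flux; a higher number here means a weaker inhibitor, a lower number a stronger inhibitor. Compound 1 gives 63.1 nM, the lowest of the two numbers in this assay. Compound 2 gives 501 nM, and the step of a 7.9-fold higher number from compound 1 to compound 2 (0.90 log units; beyond the scatter) lies beyond the scatter.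

Compound 3 `Cc1c(C(C)OC(=O)Nc2ccccc2)oc2nc(C3CC3)nn12` has not yet been measured. It differs from compound 1 by cyclopropyl in place of hydrogen on an aromatic carbon. Among the measured compounds shown here, the only measured step, from compound 1 to compound 2, concerns a chloro group on the phenyl ring of the carbamate, a different part of the molecule, so it offers no direct guide to a change on the fused core. For the measured compounds named here, with no step bearing on this position, the most plausible expectation is that the number in this assay stays close to that of compound 1, with a wide range on either side.

Compound 3 is therefore estimated at 60 nM, between 15 nM and 250 nM, an expected step of a 1.1-fold lower number from compound 1 to compound 3 (0.02 log units; within the scatter), which would be within the scatter.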

Compound 3, half-maximal inhibitory concentration: 12.6 nM
Compound 3: the middle estimate sits 4.8-fold (0.68 log units) above what was measured; the whole stated range lies above it.
By their numbers in this assay, from the lowest: compound 3; then compound 1; then compound 2.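

In this assay this position proves open to change: on the aromatic carbon between two ring nitrogen atoms, cyclopropyl in place of hydrogen gives a stronger inhibitor (a 5.0-fold lower number from compound 1 to compound 3 (0.70 log units; beyond the scatter)). Among the compounds shown here, the only earlier change, chloro on the phenyl ring of the carbamate, moved the number the other way (a 7.9-fold higher number from compound 1 to compound 2 (0.90 log units; beyond the scatter)), so this is the first sign that a change on the shared core, rather than on that phenyl ring, can lower the number. Nothing measured here accounts for the size or direction of the cyclopropyl step.

One group at this carbon cannot show whether the effect belongs to cyclopropyl in particular or would also appear with methyl, a longer chain such as propyl, a larger ring such as cyclohexyl, or an amine. As far as these compounds go, it also remains open whether cyclopropyl on the core and chloro on the phenyl ring would act independently if both stood in one molecule, or whether one change would alter the effect of the other.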